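Swapping a ring for a short chain on the amide nitrogen

The source may report more compounds than this note shows. Statements on the series, on what has been measured and on what is new or still open speak of the compounds shown alone.

Of the compounds shown here, three built on a shared core have been tested in a functional assay on the whole organism (blood, strain albino) with Mus musculus as the target, with stated times of 6 days and 3 h, at a dose of 1 mmol/kg by the oral route; a lower number here means less inhibition, a higher number more inhibition at the dose given (going by the name of the read-out). Compound 1 `Cc1cc(C(=O)O)nn1-c1ccc(S(=O)(=O)N2CCC(=O)N(C3CCCCC3)C2=S)cc1` gives 2% in this assay. Compound 2 `CCCCN1C(=O)CCN(S(=O)(=O)c2ccc(-n3nc(C(=O)O)cc3C)cc2)C1=S` gives 2%, and the step of no change at the digits printed from compound 1 to compound 2 (within the scatter) shows that exchanging the cyclohexyl for a butyl group on the ring nitrogen left the read-out where it was. Compound 3 `Cc1cc(C)n(-c2ccc(S(=O)(=O)N3CCC(=O)N(C4CCCCC4)C3=S)cc2)n1` gives 4%; the step of a number 2 percentage points higher from compound 1 to compound 3 (within the scatter) is also within the scatter. Thus compound 3, compound 1 and compound 2 all sit close to one another, with none separated from the others by more than the usual scatter, and every number is small.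

Compound 4 `CCCN1C(=O)CCN(S(=O)(=O)c2ccc(-n3nc(C)cc3C)cc2)C1=S` has not yet been measured. Its difference from compound 3 is propyl in place of cyclohexyl on an amide-type nitrogen in a ring. The closest comparison available is the step from compound 1 to compound 2, where a butyl group replaced the same cyclohexyl on the same nitrogen and the number did not move. A propyl group is a shorter chain of the same kind, so no step beyond the scatter is expected here either; the estimated step is a number 1 percentage points lower from compound 3 to compound 4 (within the scatter). For compound 4 the expected value in this assay is 3%, with a range from 0% to 12%.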

Compound 4, a percentage reported as inhibition, in the whole organism at one dose (the size of the read-out at that dose, not a potency): 1%
Compound 4: the middle estimate sits 2 percentage points above what was measured; measured number inside the range.
By their numbers in this assay, from the lowest: compounds 4, 1, 2 and 3 (each within the scatter of the next).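

The step of a number 3 percentage points lower from compound 3 to compound 4 (within the scatter) shows that on this amide-type nitrogen in the ring, cyclohexyl can give way to propyl with the number in this assay staying within the scatter, and that this holds with methyl rather than carboxy on the aromatic carbon. Alongside the step of no change at the digits printed from compound 1 to compound 2 (within the scatter) for butyl, the exchange of the cyclohexyl ring for an open chain has now been seen on two versions of the shared core, and neither step goes beyond the scatter. No measurement shown here offers any explanation for this flat result.

All four numbers are small and lie close together, so these compounds cannot tell whether the group on this nitrogen has any real influence on the read-out, or whether the whole series simply sits too low for a difference to appear. From the compounds shown here alone, a much longer chain such as octyl, a benzyl group, or a chain ending in an amine or a carboxylic acid on the same nitrogen would test this, and it remains open whether any of them would give a number clearly apart from these.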